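The source may hold more compounds than are shown below. What is called first, only, known or untested is meant among the compounds shown, and "the series" means these compounds.

Of the compounds shown here, three have been measured in an assay on NIH3T3 cells for binding affinity to melatonin receptor type 1A (Homo sapiens) (a lower number here means a stronger inhibitor, a higher number a weaker inhibitor), all built on a shared core that carries an amide-bearing side chain on an aromatic carbon. Compound 1 `CC(C)C(=O)NCCCc1cccc2c1C[C@@H](CCCCc1ccccc1)O2` gives 4 nM. Compound 2 `CCC(=O)NC[C@@H]1C[C@H]1c1cccc2c1C[C@@H](CCCCc1ccccc1)O2` gives 1 nM. Compound 3 `CCC(=O)NCCCc1cccc2c1C[C@@H](CCCCc1ccccc1)O2` gives 1 nM. Within the data shown here, the step of a 4.0-fold lower number from compound 1 to compound 3 (0.60 log units; beyond the scatter) is the only one that changes the acyl side of the amide alone. The step of a 4.0-fold lower number from compound 1 to compound 2 (0.60 log units; beyond the scatter) alters both the linker and the acyl group at once, and the step of no change at the digits printed from compound 2 to compound 3 (within the scatter) shows that the linker change by itself does not matter at the digits reported. Compound 3 therefore stands level with compound 2, and the two together hold the lowest numbers of the three.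

Compound 4 `O=C(NCCCc1cccc2c1C[C@@H](CCCCc1ccccc1)O2)C1CC1` differs from compound 3 in one place: cyclopropyl in place of ethyl on a carbonyl carbon. Among the measured compounds shown here, the single measured step on the acyl side, from compound 1 to compound 3, shows that a branched group there gave a higher number than a straight one. Compound 4 is therefore expected to give a number close to, or somewhat above, that of compound 3. The expected change is a 2.0-fold higher number from compound 3 to compound 4 (0.30 log units; within the scatter). The estimate for compound 4 in this assay is 2 nM, within a range from 0.7 nM to 6 nM.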

Compound 4, inhibition constant: 2 nM
Beside the measured number, compound 4's estimate shows no gap at the digits printed, within the range that was stated.
By their numbers in this assay, from the lowest: compounds 2, 3, 4 and 1 (each within the scatter of the next, the first and the last beyond it).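

In this assay, the step of a 2.0-fold higher number from compound 3 to compound 4 (0.30 log units; within the scatter) puts a three-membered ring of carbon on the carbonyl carbon in place of ethyl, and the result stays within the scatter, so this position accepts cyclopropyl with no change that can be told apart from repeat-measurement noise. The acyl comparison also gains a middle point: the step of a 2.0-fold lower number from compound 1 to compound 4 (0.30 log units; within the scatter) is within the scatter too, even though the step of a 4.0-fold lower number from compound 1 to compound 3 (0.60 log units; beyond the scatter) lies beyond it, so compound 4 cannot be separated from either the ethyl or the isopropyl compound, although those two are separated from each other. The step of a 2.0-fold higher number from compound 2 to compound 4 (0.30 log units; within the scatter) is also within the scatter, so swapping the whole side chain of compound 2 for 3-((cyclopropylcarbonyl)amino)propyl leaves no readable difference in this assay.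

No separate evidence is available to explain these numbers. The compounds shown leave open how this carbonyl carbon would respond to a phenyl ring, a longer chain such as butyl, or a group carrying an amine, and whether cyclopropylcarbonyl would give a similar number on the cyclopropyl-containing side chain of compound 2.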